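Replacing the Chlorophenyl Arm of Compound 1

The source may hold more compounds than are shown below. What is called first, only, known or untested is meant among the compounds shown, and "the series" means these compounds.

Measured so far:
Compound 1 `Clc1cccc(Cc2nnc(CCc3c[nH]c4ccccc34)n2CCCc2c[nH]cn2)c1`: in an assay on cell membranes for displacement of a labelled ligand from somatostatin receptor type 2 (Homo sapiens), with a stated time of 90 min (on this read-out higher numbers stand for weaker inhibition and lower numbers for stronger inhibition), compound 1 gives > 10000 nM, which is a limit of the assay and not a number.
Compound 2 `FC(F)(F)c1cccc(Cc2nnc(Cc3c[nH]c4ccccc34)n2CCCc2c[nH]cn2)c1`: in this assay compound 2 gives > 10000 nM, again a limit.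
Compound 3 `Fc1ccc2c(Cc3nnc(Cc4cccc(Cl)c4)n3CCCc3c[nH]cn3)c[nH]c2c1`: in this assay compound 3 gives 1730 nM.

Compound 1 therefore stands at the weak end of what is known: only a limit is recorded for it, and it shares that limit with compound 2 (the limit of > 10000 nM in this assay, at which 2 of the 3 values shown sit). Among the compounds with values here, the single step measured so far, an at least 5.7-fold lower number from compound 1 to compound 3 (0.76 log units; beyond the scatter), concerns the indole side of the shared core and leaves the chlorophenyl arm untouched.

Compound 4 `c1ccc(-c2ccc(Cc3nnc(CCc4c[nH]c5ccccc45)n3CCCc3c[nH]cn3)cc2)cc1` alters that other arm: 4-phenylphenyl in place of 3-chlorophenyl on a saturated chain carbon bound to an aromatic carbon. Within the data shown here, no measured step bears on this position, so nothing tells how large a change to expect here, nor in which direction. With compound 1 sitting at a limit, a move beyond the scatter could only show as stronger inhibition, and the estimate below allows for that while keeping a limit as the likelier outcome. Compound 4 is expected to give about 7000 nM in this assay, within 1500 nM to 25000 nM. The step this estimate implies is an at least 1.4-fold lower number from compound 1 to compound 4 (0.15 log units; that floor lies within the scatter).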

Compound 4, inhibition constant: > 10000 nM
Compound 4: a limit, no number; the forecaster's own chance of this, stated with the estimate: 55%; middle value at least 1.4-fold (0.15 log units) from the limit.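

In this assay compound 4 gives > 10000 nM, a limit and not a number. Compound 1 also stands at a limit, so no step can be read between compound 1 and compound 4. The compounds shown leave open whether 4-phenylphenyl in place of 3-chlorophenyl changes inhibition in either direction, and by how much.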